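The compounds below may be only part of what the source reports. "The series", "measured", "known", "first", "only" and "open" are said of these compounds alone.

The measured compounds:
compound 1, `Fc1ccccc1CN(Cc1nnn[nH]1)c1ccccc1`; in a physicochemical assay for lipophilicity, using the shake flask method, measured as octanol-water partition, with a stated time of 24 h, at 25 degrees C (on this read-out higher numbers stand for higher lipophilicity and lower numbers for lower lipophilicity), compound 1 gives 1.28.
compound 2, `COc1ccc(N(Cc2nnn[nH]2)Cc2ccc(Cl)cc2Cl)cc1`; in this assay compound 2 gives 1.58.
compound 3, `CCCCCCN(Cc1nnn[nH]1)c1ccccc1`; in this assay compound 3 gives 2.18.

Compound 1 stands lowest of the three numbers. Its nearest neighbour is compound 2, whose value lies within the scatter of that of compound 1, so the two cannot be placed in order. Going by the values given here, compound 3 lies furthest away: the step of a number 0.90 log units higher from compound 1 to compound 3 (beyond the scatter) is the only one among the measured compounds that changes a single place.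

Compound 4, `Fc1cccc(CN(Cc2nnn[nH]2)c2ccccc2)c1`, has not yet been measured. It differs from compound 1 in one place: 3-fluorophenyl in place of 2-fluorophenyl on a saturated chain carbon bound to a nitrogen on an aromatic ring. Among the compounds with values here, the measured step of a number 0.90 log units higher from compound 1 to compound 3 (beyond the scatter) shares the place of the change but exchanges the whole group for a chain, so it bears on compound 4 only loosely; no measured pair swaps one fluorophenyl for another. On the data at hand, the step from compound 1 to compound 4 is expected to be small, a number 0.12 log units higher from compound 1 to compound 4 (within the scatter), and not beyond the scatter. Compound 4 is therefore estimated to give about 1.4 in this assay, with a range from 1.1 to 1.7.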

Compound 4, partition coefficient: 1.29
The estimate for compound 4 lay 0.11 log units above the measured number; low and high end bracket the measured number.
By their numbers in this assay, from the lowest: compounds 1, 4 and 2 (each within the scatter of the next); then compound 3.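

Going by these compounds alone, exchanging 2-fluorophenyl for 3-fluorophenyl on a saturated chain carbon bound to a nitrogen on an aromatic ring gives the first comparison of two fluorophenyl groups at this place, and in this assay the result is a number 0.01 log units higher from compound 1 to compound 4 (within the scatter). Although the two groups have the same atoms joined differently, this exchange leaves no readable difference, while the other exchange at this place still gives a clear one: a number 0.89 log units lower from compound 3 to compound 4 (beyond the scatter). Among these compounds, then, the two fluorophenyl groups cannot be told apart at this place, whereas the pentyl of compound 3 stands clearly apart from both, and nothing available offers an explanation for either finding.

From the compounds shown here alone, whether the same holds for a phenyl without fluorine, for a phenyl bearing a trifluoromethyl group or for a longer chain such as octyl remains open. Compound 2 differs from each of the others in more than one place, so the separate contributions of its changes also remain unresolved.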